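Replacing a Urea Arm: From Compound 1 to Compound 3

A few compounds are considered here, and "the series" means these few. Any claim that something is new, unique, unknown or untested is made for them only; others in the source may bear on it.

The series starts from compound 1 `COc1cc(-c2nn(-c3cccc(NC(=O)Nc4ccc(Cl)c(Cl)c4)c3)cc2-c2ccncc2)ccc1Cl` and its close relative compound 2 `O=C(Nc1cccc(-n2cc(-c3ccncc3)c(-c3ccc(Cl)c(O)c3)n2)c1)Nc1ccc(Cl)c(Cl)c1`, both tested in a functional assay on PC-3 cells (Homo sapiens) for inhibition, read by sulforhodamine B assay, with a stated time of 48 h; on this read-out lower numbers stand for stronger inhibition and higher numbers for weaker inhibition. Compound 1 gives 550 nM, the lowest of the two numbers shown, while compound 2 gives 830 nM. Going by the values given here, the only step measured so far, a 1.5-fold higher number from compound 1 to compound 2 (0.18 log units; within the scatter), comes from hydrogen in place of methyl on an oxygen on an aromatic ring and stays within the scatter, so the two compounds cannot be ordered.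

Compound 3 `COc1cc(-c2nn(-c3cccc(NC(=O)c4ccc(Cl)c(C(F)(F)F)c4)c3)cc2-c2ccncc2)ccc1Cl` is not yet measured. It differs from compound 1 by 4-chloro-3-(trifluoromethyl)phenyl in place of (3,4-dichlorophenyl)amino on a carbonyl carbon. Among the compounds with values here, no measured step touches this part of the molecule: the step from compound 1 to compound 2 changes a different ring and therefore gives no direct guide. Within the data shown here, the only anchor is the value of compound 1 itself, 550 nM, so the expectation for compound 3 is built on that anchor alone, with a wide range to allow for an unknown effect of the change.

Compound 3 is therefore expected to show about 650 nM in this assay, within roughly 200 nM to 2200 nM, which means an expected step of a 1.2-fold higher number from compound 1 to compound 3 (0.07 log units; within the scatter) from compound 1, not clearly beyond the scatter.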

Compound 3, half-maximal inhibitory concentration: 1290 nM
Beside the measured number, compound 3's estimate is 2.0-fold (0.30 log units) below it; low and high end bracket the measured number.
By their numbers in this assay, from the lowest: compounds 1, 2 and 3 (each within the scatter of the next, the first and the last beyond it).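

At this carbonyl carbon, the change has a measurable effect in this assay: the swap gives a 2.3-fold higher number from compound 1 to compound 3 (0.37 log units; beyond the scatter) and, unlike the earlier change on the oxygen, moves beyond the usual scatter. The step is modest, and compound 3 at 1290 nM still registers inhibition, so replacing (3,4-dichlorophenyl)amino with 4-chloro-3-(trifluoromethyl)phenyl weakens the result without abolishing it. No supporting measurement is available to explain the higher number.

The swap alters two things at once, since the amino nitrogen, which carries the hydrogen-bond donor counted in the leaving group, disappears while the ring substituents also differ, so these compounds cannot show how much of the step belongs to either part. A (4-chloro-3-(trifluoromethyl)phenyl)amino group or a plain 3,4-dichlorophenyl group on the same carbonyl carbon would separate the two parts, and an open question is whether a ring-free group there, such as a simple alkyl amine, would keep any inhibition in this assay at all.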